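The compounds below may be only part of what the source reports. "The series", "measured", "known", "first", "only" and "open" are said of these compounds alone.

Compound 3 `CN1CCC[C@@H]1Cn1nc(CCc2ccccc2)c2ccccc2c1=O` carries a phenethyl chain on the shared core, and in an assay for binding affinity to Alpha-1A adrenergic receptor (Homo sapiens) (a higher number here means a weaker inhibitor, a lower number a stronger inhibitor), compound 3 gives 200 nM. Going by the values given here, compound 2 `CN1CCCCC(n2nc(Cc3ccc(Cl)cc3)c3ccccc3c2=O)C1` gives 158 nM in this assay, a value that sits within the scatter of the one for compound 3, so the two cannot be ranked. Compound 1 `CN1CCC[C@@H]1Cn1nc(CC2CCCCC2)c2ccccc2c1=O` reaches only a limit in this assay, recorded as > 1990 nM (the limit of > 1990 nM in this assay, at which 1 of the 3 values shown sits). Among the compounds with values here, the one step measured between close relatives, an at least 9.9-fold lower number from compound 1 to compound 3 (0.99 log units; beyond the scatter), is therefore the only size reference in this set, and it concerns a different exchange from the one now in question.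

Compound 4 `COc1ccc(Cc2nn(C[C@H]3CCCN3C)c(=O)c3ccccc23)cc1` differs from compound 3 by 4-methoxyphenyl in place of benzyl on a saturated chain carbon bound to an aromatic carbon. No measured pair tests the addition of a methoxy group on the aromatic ring, so the step from compound 3 is not covered by any shown step, and the account can only note that the aromatic ring itself is retained. The expectation is therefore a number close to that of compound 3, with no step beyond the scatter: no change at the digits printed from compound 3 to compound 4 (within the scatter). For compound 4 the estimated value in this assay is 200 nM, expected to lie between 60 nM and 700 nM.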

Compound 4, inhibition constant: 126 nM
Estimate against measurement, compound 4: 1.6-fold (0.20 log units) above; the measured number falls inside the stated range.
By their numbers in this assay, from the lowest: compounds 4, 2 and 3 (each within the scatter of the next). At a limit, above all of these: compound 1.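

In this assay, 4-methoxyphenyl in place of benzyl on a saturated chain carbon bound to an aromatic carbon gives a 1.6-fold lower number from compound 3 to compound 4 (0.20 log units; within the scatter), so phenethyl and 4-methoxybenzyl cannot be told apart at this position, even though this exchange changes the chain and adds a methoxy group in one move. The exchange of cyclohexyl for 4-methoxyphenyl is of another size, an at least 15-fold lower number from compound 1 to compound 4 (1.19 log units; beyond the scatter), and it stands with an at least 9.9-fold lower number from compound 1 to compound 3 (0.99 log units; beyond the scatter), so both compounds shown here with an aromatic ring at this place lie beyond the scatter from the compound with cyclohexyl. Compound 1 stands at a limit and not at a number, which leaves the full size of both steps unknown: the limit of > 1990 nM in this assay, at which 1 of the 4 values shown sits.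

Since the chain and the ring substituent change together from compound 3 to compound 4, the compounds shown do not separate what each contributes, and a 4-methoxyphenethyl chain or an unsubstituted benzyl group on the same core would be needed to do so. On these data alone, what a hydroxyl group, a fluorine atom or an amine on the aromatic ring would give, or a longer chain such as phenylpropyl, also stays open.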